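Turning the Ring Stereocentre of Compound 2

The compounds below may be only part of what the source reports. "The series", "measured", "known", "first", "only" and "open" are said of these compounds alone.

Measured so far:
compound 1, `Cc1c(C)c2c(c(C)c1O)CC[C@@](C)(CC[S+](C)C)O2`, 2000 nM
compound 2, `Cc1c(C)c2c(c(C)c1O)CC[C@](C)(CCN(C)C)O2`, 1000 nM

Both compounds were tested in a functional assay (brain) for inhibition, with Rattus norvegicus as the target; on this read-out lower numbers stand for stronger inhibition and higher numbers for weaker inhibition. Among the measured compounds shown here, compound 2 gives the lower of the two numbers; the only other number, that of compound 1, differs from it by a gap that stays within the usual scatter of repeated measurements, so the two cannot be told apart on potency.

Compound 3, `Cc1c(C)c2c(c(C)c1O)CC[C@@](C)(CCN(C)C)O2`, has not been measured. It differs from compound 2 as follows: the two compounds have the same atoms and bonds and differ only in configuration as drawn: 1 of 1 stereo elements differ; a stereocentre at a saturated ring carbon is drawn R in compound 2 and S in compound 3. For the measured compounds named here, no step between two measured compounds of this kind is available, so there is nothing here to say how large an effect this change has, or in which direction. Because compound 2 gives 1000 nM, and because compound 1 gives 2000 nM, the expectation is that compound 3 will land close to these two numbers. The estimated step from compound 2 to compound 3 is a 1.5-fold higher number from compound 2 to compound 3 (0.18 log units; within the scatter), with the direction uncertain. Compound 3 is expected to give 1500 nM, within a range of 400 nM to 6000 nM.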

Compound 3, half-maximal inhibitory concentration: 1000 nM
Compound 3: middle estimate off by 1.5-fold (0.18 log units), on the high side; measured number inside the range.
By their numbers in this assay, from the lowest: compounds 2, 3 and 1 (each within the scatter of the next).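

In this assay, among the compounds shown here, turning the ring stereocentre from R to S gives no change at the digits printed from compound 2 to compound 3 (within the scatter), which is the first direct look at this position, and the drawn configuration there shows no effect that this read-out can separate from ordinary scatter. This pair tests the stereocentre alone, with no other feature of the molecule involved, and the reading rests on a single fact: the fact that compounds 2 and 3 differ only in the configuration as drawn

For the compounds shown here, the new compound also gives the first one-place comparison at the chain end, where a group of two carbons and one nitrogen replaces a group of two carbons and one sulfur, giving a 2.0-fold lower number from compound 1 to compound 3 (0.30 log units; within the scatter), so this exchange cannot be told apart from scatter either.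

Going by these compounds, what remains open is whether the stereocentre would begin to matter with a different chain, such as a longer chain or one ending in a carboxylic acid. The compounds shown also leave open which part of the molecule the inhibition depends on, and a methoxy group in place of the hydroxyl on the shared core would test one such part.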